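From Methyl to Fluoro on an Inactive Sulfonamide

The source may report more compounds than this note shows. Statements on the series, on what has been measured and on what is new or still open speak of the compounds shown alone.

Compound 1 `Cc1ccccc1S(=O)(=O)Nc1ccc2oc(-c3ccccc3)nc2c1` carries a 2-methylphenyl sulfonamide on the shared core. In an assay on cells for inhibition of HSP60/HSP10 (Homo sapiens), with a stated time of 60 min (a higher number here means a weaker inhibitor, a lower number a stronger inhibitor), compound 1 reaches only a limit, > 100000 nM, so no number fixes its potency. The two measured analogues bear a different sulfonyl group: compound 2 `O=S(=O)(Nc1ccc2oc(-c3ccc(NS(=O)(=O)c4cccc5nonc45)cc3)nc2c1)c1ccc(Cl)s1` gives 13000 nM, compound 3 `CS(=O)(=O)Nc1ccc(-c2nc3cc(NS(=O)(=O)c4ccc(Cl)s4)ccc3o2)cc1` gives 43000 nM, and the step of a 3.3-fold higher number from compound 2 to compound 3 (0.52 log units; beyond the scatter) concerns the far side of the molecule. Compound 4 `O=S(=O)(Nc1ccc2oc(-c3ccccc3)nc2c1)c1ccccc1F` differs from compound 1 by fluoro in place of methyl on an aromatic carbon. For the measured compounds named here, no measured step touches this position, and compound 1 itself sits at the limit of > 100000 nM in this assay, at which 1 of the 3 values shown sits, so there is no ground for a large shift. For compound 4 the expected step is a step that the limit leaves unreadable from compound 1 to compound 4, nothing beyond the scatter. The estimate for compound 4 is 150000 nM, between 50000 nM and 450000 nM.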

Compound 4, half-maximal inhibitory concentration: > 100000 nM
Compound 4 was reported as a limit (the forecaster's own chance of this, stated with the estimate: 75%); the middle value does not contradict the limit.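

Compound 1 and compound 4 both stand only as limits, so no step between them can be read: the limit of > 100000 nM in this assay, at which 2 of the 4 values shown sit.

Going by these compounds, whether fluoro in place of methyl shifts potency at all on the shared core remains open.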